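This account rests on a few compounds, and the source may have more. Where it says the series, first, only, none or still open, it means among the compounds named here.

Measured so far in an ADME assay on Vero cells (Chlorocebus sabaeus) for cytotoxicity, with a stated time of 72 h; on this read-out lower numbers stand for higher toxicity in this test and higher numbers for lower toxicity in this test:

- compound 1 `CN1CCN(c2ccc(C(=O)/C=C/c3ccc(Cl)cc3)cc2)CC1`: 102 ug/mL
- compound 2 `CCCCN(CCCC)c1ccc(C(=O)C2CC2c2ccc(Cl)cc2)cc1`: 431 ug/mL
- compound 3 `COc1ccc(C2CC2C(=O)c2ccc(N3CCN(C)CC3)cc2)cc1OC`: 77.8 ug/mL

Compound 2 stands highest of the three numbers in this assay. Its nearest neighbour is compound 1, whose value is lower by a margin beyond the usual scatter; compound 3 lies further still, also beyond the scatter. Compound 2 is therefore the least toxic of the three in this test, while compound 1 and compound 3 sit within the scatter of each other and are not ranked against one another.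

The next compound, compound 4 `O=C(c1ccc(NCCn2cncn2)cc1)C1CC1c1ccc(Cl)cc1`, has not yet been measured in this assay. It differs from compound 2 in one place: (2-(1H-1,2,4-triazol-1-yl)ethyl)amino in place of dibutylamino on an aromatic carbon. The dibutylamino group leaves and the (2-(1H-1,2,4-triazol-1-yl)ethyl)amino group enters on the aromatic carbon. Going by the values given here, no measured pair in the set shares this change, so no step can be read off directly; the only guide is that compound 2 carries the highest number and the two other substituents on that aromatic carbon give lower values.

The step from compound 2 to compound 4 is expected to be downward, of a size beyond the scatter, as a 2.7-fold lower number from compound 2 to compound 4 (0.43 log units; beyond the scatter). Compound 4 is estimated at 160 ug/mL, within a range from 50 ug/mL to 500 ug/mL.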

Compound 4, half-maximal cytotoxic concentration: 39.9 ug/mL
Compound 4: middle estimate off by 4.0-fold (0.60 log units), on the high side, and the stated range ends above it.
By their numbers in this assay, from the lowest: compounds 4, 3 and 1 (each within the scatter of the next, the first and the last beyond it); then compound 2.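

In this assay, replacing dibutylamino with (2-(1H-1,2,4-triazol-1-yl)ethyl)amino on the aromatic carbon para to a large group gives an 11-fold lower number from compound 2 to compound 4 (1.03 log units; beyond the scatter) and counts as a large step. Going by these compounds alone, this is the first single-place comparison, and it shows that the substituent at this position alone can shift the cytotoxicity read-out well beyond the scatter, towards higher toxicity in this test.

The change replaces a chain with no ring by a group that brings a five-membered aromatic ring and a hydrogen-bond donor, and the compounds shown do not separate these two features. Butylamino or diethylamino at this carbon on the same core would help to show which feature goes with the step, and their place in this assay remains open.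

No measurement available here accounts for the size or direction of this step.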